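Chloro for phenyl at the aryl substituent: expected recovery

The compounds below may be only part of what the source reports. "The series", "measured", "known", "first", "only" and "open" are said of these compounds alone.

Within the data shown here, compound 2 `CS(=O)(=O)c1ccc(N2N=C(c3ccc(-c4ccccc4)cc3)CCC2=O)cc1` stands lowest of the two numbers so far: in a functional assay on the whole organism (strain Wistar) for inhibition, with Rattus norvegicus as the target, read by paw edema, with stated times of 30 min and 5 h, at a dose of 0.05 mmol/kg by the oral route (on this read-out lower numbers stand for less inhibition and higher numbers for more inhibition at the one dose given (going by the name of the read-out)), compound 2 gives 21%, whereas compound 1 `COc1ccc(C2=NN(c3ccc(S(C)(=O)=O)cc3)C(=O)CC2)cc1` gives 68.4%. Among the measured compounds shown here, the one step known, a number 47.4 percentage points lower from compound 1 to compound 2 (beyond the scatter), arose from phenyl in place of methoxy. Compound 3 `CS(=O)(=O)c1ccc(N2N=C(c3ccc(Cl)cc3)CCC2=O)cc1` differs from compound 2 by chloro in place of phenyl on an aromatic carbon. As this removes the phenyl whose arrival went with the large fall, a rise beyond the scatter is expected, though chloro is not methoxy and the full return is uncertain. Compound 3 is estimated at 50% in this assay, range 25% to 75%, a step of a number 29 percentage points higher from compound 2 to compound 3 (beyond the scatter).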

Compound 3, a percentage reported as inhibition, in the whole organism at one dose (the size of the read-out at that dose, not a potency): 36.8%
The estimate for compound 3 lay 13.2 percentage points above the measured number; the measured number falls inside the stated range.
By their numbers in this assay, from the lowest: compound 2; then compound 3; then compound 1.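

At this aromatic carbon, para to a large group, removing the phenyl brings back only part of the fall: chloro in place of phenyl gives a number 15.8 percentage points higher from compound 2 to compound 3 (beyond the scatter) and chloro in place of methoxy gives a number 31.6 percentage points lower from compound 1 to compound 3 (beyond the scatter) so chloro falls short of methoxy. Among these three groups, the order runs phenyl, chloro, methoxy from the lowest number to the highest. Nothing available explains this order.

As far as these compounds go, it remains open whether a hydroxyl, an ethoxy or a dimethylamino group here would match methoxy. From the compounds shown here alone, whether the order holds at other doses also stays open.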